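This account rests on a few compounds, and the source may have more. Where it says the series, first, only, none or still open, it means among the compounds named here.

Measured compounds:
Compound 1 `COc1ccc(Cn2cc(/C=N\NC(=O)c3c[nH]c4ccc(Br)cc34)c3cc(OC)ccc32)cc1`, 44500 nM
Compound 2 `O=C(N/N=C\c1cn(Cc2ccc(Cl)cc2)c2cc(F)ccc12)c1c[nH]c2ccccc12`, 18000 nM
Compound 3 `Cn1cc(C(=O)N/N=C\c2cn(Cc3ccc(Cl)cc3)c3cc(F)ccc23)c2ccccc21`, 50400 nM

These values come from a functional assay on MIA PaCa-2 cells (Homo sapiens) for cytotoxicity; a higher number here means a weaker inhibitor, a lower number a stronger inhibitor. Among the three, compound 2 gives the lowest number, so it is the strongest inhibitor of the set; compound 1 and compound 3 both sit beyond the usual scatter above it. Among the measured compounds shown here, the one single-point step seen so far, a 2.8-fold higher number from compound 2 to compound 3 (0.45 log units; beyond the scatter), concerns the hydrogen on an aromatic nitrogen and does not touch the part of the molecule changed here.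

Compound 4 `COc1ccc(Cn2cc(/C=N\NC(=O)c3c[nH]c4ccccc34)c3ccc(F)cc32)cc1` is the unmeasured compound. It differs from compound 2 by methoxy in place of chloro on an aromatic carbon. For the measured compounds named here, no measured step bears directly on this change. Compound 1, which also carries a 4-methoxybenzyl group, gives a higher number than compound 2, but it differs from compound 2 in several other places too, so its value is only a loose hint. The expected step is therefore small, if any, and more likely upward: a 1.7-fold higher number from compound 2 to compound 4 (0.22 log units; within the scatter). Compound 4 is estimated at 30000 nM, with a range from 12000 nM to 80000 nM.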

Compound 4, half-maximal inhibitory concentration: 43300 nM
Compound 4: middle estimate off by 1.4-fold (0.16 log units), on the low side; the range from low to high includes it.
By their numbers in this assay, from the lowest: compound 2; then compounds 4, 1 and 3 (each within the scatter of the next).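

In this assay, among the compounds shown here, replacing 4-chlorobenzyl with 4-methoxybenzyl gives a 2.4-fold higher number from compound 2 to compound 4 (0.38 log units; beyond the scatter) and provides the first direct reading of a change at this position. The earlier step concerned the hydrogen on an aromatic nitrogen, whereas this one shows that exchanging chloro for methoxy alone moves the number beyond the usual scatter, towards a weaker inhibitor. No measurement shown gives a reason for this step.

As far as these compounds go, with only these two groups compared at this position, it remains open how a methyl, a nitrile or an amine in the same place would stand against chloro and methoxy. From the compounds shown here alone, it is also open whether the exchange would give a step of similar size in a compound carrying the methyl on the aromatic nitrogen, as compound 3 does.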